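Working notes: from compound 1 to compound 3

A few compounds are considered here, and "the series" means these few. Any claim that something is new, unique, unknown or untested is made for them only; others in the source may bear on it.

- compound 1 `CC(=O)N1CCC(c2ccc3c(c2)oc(=O)n3C(=O)NCCCCc2ccccc2)CC1`: 0.5 h
- compound 2 `O=C(NCCCCc1ccccc1)n1c2c(oc1=O)CNCC2`: > 2 h

Within the data shown here, in an ADME assay on a cell-free system (plasma, Mus musculus) for metabolic stability, read by LC-MS, tested at 2 uM (on this read-out higher numbers stand for a longer-lived compound and lower numbers for a shorter-lived compound), compound 1 gives 0.5 h, the only true number so far in this small set. Compound 2 gives > 2 h, which is a limit of the assay and not a number.

Compound 3 `CN1CCN(c2ccc3c(c2)oc(=O)n3C(=O)NCCCCc2ccccc2)CC1` is the next to be read in this assay. It keeps the core of compound 1 and carries a 4-methylpiperazin-1-yl in place of 1-acetylpiperidin-4-yl on an aromatic carbon. Among the measured compounds shown here, no measured pair shows what a change at this place does, and compound 2 has a different core, so it offers little guidance here.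

The expectation therefore rests on compound 1 at 0.5 h, and no step beyond the scatter is expected, with neither direction favoured. The expected step is no change at the digits printed from compound 1 to compound 3 (within the scatter). For compound 3 the estimated half-life is 0.5 h, with an expected range of 0.2 h to 1.3 h.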

Compound 3, half-life: < 0.0834 h
Compound 3: a limit, no number; the forecaster's own chance of this, stated with the estimate: 5%; at least 5.9-fold (0.77 log units) between middle value and limit.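

This aromatic carbon of the shared core is not a silent place in this assay: 4-methylpiperazin-1-yl in place of 1-acetylpiperidin-4-yl gives an at least 5.9-fold lower number from compound 1 to compound 3 (0.77 log units; beyond the scatter), a step that compound 2, with its different core, could not reveal. Compound 3 gives < 0.0834 h, which is a limit of the assay and not a number, so the step has a known minimum but no known size: the limit of < 0.0834 h in this assay, at which 1 of the 3 values shown sits. The change replaces the ring and its substituent in a single move, and this one step does not show which part carries the loss of half-life, nor does it support a cause.

A 4-acetylpiperazin-1-yl at this place would keep the acetyl of compound 1 and the ring of compound 3, while a 1-methylpiperidin-4-yl would keep the ring of compound 1 and the methyl of compound 3, and the compounds shown leave open where either would fall in this assay. Also open, as far as these compounds go, is whether the same step appears on any core other than that of compound 1, and whether it holds with a chain other than the 4-phenylbutyl chain common to all three compounds.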